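Aryl exchange on the shared core: compound 3 to compound 4

The source may report more compounds than this note shows. Statements on the series, on what has been measured and on what is new or still open speak of the compounds shown alone.

Within the three compounds measured, compound 3 `Cc1ccc(-c2cc3c(cn2)ncn3-c2ccc(OC(F)F)cc2)c(C)c1` stands second highest in a functional assay on HL-60 cells (Homo sapiens) for activation, read by flow cytometry, with a stated time of 4 days; on this read-out higher numbers stand for an effect only at larger amounts of compound and lower numbers for an effect already at smaller amounts: compound 3 gives 180 nM. Its nearest neighbour is compound 2 `COc1ccc(-n2cnc3cnc(-c4ccccc4C)cc32)cc1OC`, and compound 2 gives 69 nM. Furthest away is compound 1 `COc1ccc(-n2cnc3cnc(-c4ccccc4)cc32)cc1OC`, and compound 1 gives 1600 nM, the highest number of the set. Among the measured compounds shown here, the only one-place step measured so far is a 23-fold lower number from compound 1 to compound 2 (1.37 log units; beyond the scatter), a large effect from a single methyl on an aromatic carbon.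

Compound 4 `Cc1nc(F)ccc1-c1cc2c(cn1)ncn2-c1ccc(OC(F)F)cc1` differs from compound 3 in one place: 6-fluoro-2-methylpyridin-3-yl in place of 2,4-dimethylphenyl on an aromatic carbon. For the measured compounds named here, the entering group keeps a methyl, so the measured step of a 23-fold lower number from compound 1 to compound 2 (1.37 log units; beyond the scatter) bears on this change only in that the methyl is retained rather than gained; no measured pair in this set covers the other parts of the exchange, the ring nitrogen and the fluorine that enter or the second methyl that leaves. With nothing in the data pointing either way, the expected step in this assay is none beyond the scatter, and the estimate for compound 4 is 200 nM, with a range from 70 nM to 600 nM, which corresponds to an expected step of a 1.1-fold higher number from compound 3 to compound 4 (0.05 log units; within the scatter).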

Compound 4, half-maximal effective concentration: 2000 nM
Estimate against measurement, compound 4: 10-fold (1.00 log units) below, and the stated range ends below it.
By their numbers in this assay, from the lowest: compound 2; then compound 3; then compounds 1 and 4 (each within the scatter of the next).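

At this aromatic carbon of the shared core, the exchange gives a large step in this assay: an 11-fold higher number from compound 3 to compound 4 (1.05 log units; beyond the scatter). A methyl retained on the entering ring therefore does not keep the number low, so the large step of a 23-fold lower number from compound 1 to compound 2 (1.37 log units; beyond the scatter) cannot be read as a rule that a methyl at this place is enough. The position also proves sensitive to a change that leaves the heavy-atom count of the group unaltered, with one six-membered aromatic ring leaving and another entering, and nothing available here ties the step to any single part of the exchange.

On these data alone, the ring nitrogen, the fluorine and the loss of the second methyl all change together in this one step, so their separate shares remain open, as does whether the step would have the same size on the core of compound 1 with its own aryl group. A 2-methylpyridin-3-yl without the fluorine, a 2-methylphenyl carrying a fluorine, or a 6-fluoro ring with a nitrile or an amine in place of the fluorine would be the groups that separate these parts.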